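Replacing the aniline ring of compound 3 with cyclopentyl

The source may report more compounds than this note shows. Statements on the series, on what has been measured and on what is new or still open speak of the compounds shown alone.

compound 1 `COc1cccc(NC2=CC(=O)c3nc4n(c3C2=O)[C@H]2OC[C@@H](O)[C@H]2OC4)c1`: 4280 nM
compound 2 `O=C1C=C(Nc2ccccc2)C(=O)c2c1nc1n2[C@H]2OC[C@@H](O)[C@H]2OC1`: 5620 nM
compound 3 `O=C1C=C(Nc2cccc(Cl)c2)C(=O)c2c1nc1n2[C@H]2OC[C@@H](O)[C@H]2OC1`: 6040 nM

All three were measured in a functional assay on HeLa cells (Homo sapiens) for inhibition, read by sulforhodamine B assay; on this read-out lower numbers stand for stronger inhibition and higher numbers for weaker inhibition. Compound 3 carries the highest of the three numbers, yet every gap is within the scatter: a 1.1-fold higher number from compound 2 to compound 3 (0.03 log units; within the scatter), a 1.4-fold higher number from compound 1 to compound 3 (0.15 log units; within the scatter) and a 1.3-fold higher number from compound 1 to compound 2 (0.12 log units; within the scatter). Compound 4 `O=C1C=C(NC2CCCC2)C(=O)c2c1nc1n2[C@H]2OC[C@@H](O)[C@H]2OC1` differs from compound 3 in that (cyclopentyl in place of 3-chlorophenyl on an amine nitrogen). For the measured compounds named here, none of the measured steps bears directly on this change, since each of them only swaps one group on the aromatic ring; all were within the scatter, so the ring tolerated those swaps, but nothing shows what a cyclopentyl does in this assay. The step expected is a 1.1-fold higher number from compound 3 to compound 4 (0.03 log units; within the scatter), none beyond the scatter, with a wide margin. Compound 4 is therefore estimated at 6500 nM, ranging from 2000 nM to 25000 nM.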

Compound 4, half-maximal inhibitory concentration: > 16000 nM
Compound 4: no number, only a limit (the forecaster's own chance of this, stated with the estimate: 15%); at least 2.4-fold (0.39 log units) between middle value and limit.
By their numbers in this assay, from the lowest: compounds 1, 2 and 3 (each within the scatter of the next). At a limit, above all of these: compound 4.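

The reading for compound 4 is a limit of the assay and not a number: the limit of > 16000 nM in this assay, at which 1 of the 4 values shown sits. Swaps on the aromatic ring had stayed within the scatter, but replacing the whole ring on the amine nitrogen with cyclopentyl gives an at least 2.6-fold higher number from compound 3 to compound 4 (0.42 log units; beyond the scatter), an at least 2.8-fold higher number from compound 2 to compound 4 (0.45 log units; beyond the scatter) and an at least 3.7-fold higher number from compound 1 to compound 4 (0.57 log units; beyond the scatter). This position therefore accepted the three aromatic groups alike, while cyclopentyl did not hold that level. Still open, from the compounds shown here alone, is whether the aromatic ring itself matters, or whether a pyridyl, a benzyl or a cyclohexyl group on that nitrogen would keep the level of compound 1, compound 2 and compound 3.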